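Saturated ring nitrogen replaces the anilino link on a pyridine core

The source may hold more compounds than are shown below. What is called first, only, known or untested is meant among the compounds shown, and "the series" means these compounds.

Compound 2 `Cc1ccc(Cl)cc1Nc1nc(C(F)(F)F)ccc1CNC(=O)C(C)c1ccc(NS(C)(=O)=O)c(F)c1`: 140 nM
Compound 1 `CC1CCC(Nc2nc(C(F)(F)F)ccc2CNC(=O)C(C)c2ccc(NS(C)(=O)=O)c(F)c2)CC1`: 1130 nM
Compound 3 `C[C@H](C(=O)NCc1ccc(C(F)(F)F)nc1N1CCC[C@H]1C(=O)N(C)C)c1ccc(NS(C)(=O)=O)c(F)c1`: "not active" (no number reported)

In a functional assay on CHO-K1 cells for antagonist activity at transient receptor potential cation channel subfamily V member 1 (Homo sapiens), read by FLIPR (a higher number here means a weaker inhibitor, a lower number a stronger inhibitor), compound 2 gives 140 nM, the lowest number among the two compounds with a reported value; its nearest neighbour is compound 1 at 1130 nM, and compound 3 is recorded as "not active" (no number reported) without a number. Among the measured compounds shown here, the one measured step, an 8.1-fold lower number from compound 1 to compound 2 (0.91 log units; beyond the scatter), shows that swapping the cycloalkyl amine for the aryl amine at the same nitrogen helped. Compound 4 `CC(C(=O)NCc1ccc(C(F)(F)F)nc1N1CCC(C)(C)CC1)c1ccc(NS(C)(=O)=O)c(F)c1` goes the other way and further: 4,4-dimethylpiperidin-1-yl in place of (5-chloro-2-methylphenyl)amino on an aromatic carbon. For the measured compounds named here, compound 3 is the only measured compound that also carries a saturated ring nitrogen in that place, and it shows no activity, though it differs from compound 2 in more than one place, so no single step can be drawn from it. Taken together, compound 1 and compound 3 point toward a weaker inhibitor, so compound 4 is expected to give 2500 nM, within 500 nM to 12000 nM. That estimate corresponds to an expected step of an 18-fold higher number from compound 2 to compound 4 (1.25 log units; beyond the scatter), beyond the scatter, with a real chance that only a limit is reported.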

Compound 4, half-maximal inhibitory concentration: 8 nM
Compound 4: the middle estimate sits 310-fold (2.49 log units) above what was measured; measured number outside the range, below it.
By their numbers in this assay, from the lowest: compound 4; then compound 2; then compound 1.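

At this place, on an aromatic carbon next to the ring nitrogen, an 18-fold lower number from compound 2 to compound 4 (1.24 log units; beyond the scatter) in this assay, so an aromatic ring on a linking nitrogen is not required for a low number, and neither is a hydrogen-bond donor, of which 4,4-dimethylpiperidin-1-yl has none. The change from the saturated (4-methylcyclohexyl)amino group gives a 140-fold lower number from compound 1 to compound 4 (2.15 log units; beyond the scatter), which means that saturated rings at this place mark both ends of the three numbers. A saturated ring nitrogen alone does not ensure activity, as compound 3 also carries one and is recorded as "not active" (no number reported). No measurement shown bears on the reason for these differences. The compounds shown leave open what the two methyl groups contribute: how piperidin-1-yl without them or morpholin-4-yl would read at this place remains unknown.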